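Four stereocentres inverted in a cytotoxic tetrahydropyran series

A few compounds are considered here, and "the series" means these few. Any claim that something is new, unique, unknown or untested is made for them only; others in the source may bear on it.

Of the compounds shown here, three of one family have been measured for cytotoxicity. Compound 1 `COc1ccc([C@H]2OC[C@H]([C@@H](O)c3ccc(OC)c(OC)c3)C[C@@H]2C/C=C/c2ccccc2)cc1OC`, compound 2 `COc1ccc(/C=C/C[C@H]2C[C@@H]([C@@H](O)c3ccccc3)CO[C@@H]2c2ccc(OC)c(OC)c2)cc1OC` and compound 3 `COc1ccc(/C=C/C[C@@H]2C[C@H]([C@H](O)c3ccc(OC)c(OC)c3)CO[C@H]2c2ccc(OC)c(OC)c2)cc1OC` share a core that carries a styryl chain, a dimethoxyphenyl ring and a secondary alcohol bearing an aryl ring. In a functional assay on HeLa cells (Homo sapiens) for cytotoxicity, read by WST assay, with a stated time of 48 h (a higher number here means a weaker inhibitor, a lower number a stronger inhibitor), compound 1 gives 14800 nM, compound 2 gives 15500 nM and compound 3 gives 28700 nM. Compound 3 has the highest of the three numbers, but its gap to compound 2 and its gap to compound 1 both lie within the usual scatter, so no order among the three can be read from these values.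

Compound 4 `COc1ccc(/C=C/C[C@H]2C[C@@H]([C@@H](O)c3ccc(OC)c(OC)c3)CO[C@@H]2c2ccc(OC)c(OC)c2)cc1OC` is the next compound to be measured. Its difference from compound 3 is counted as follows: the two compounds have the same atoms and bonds and differ only in configuration as drawn: 4 of 5 stereo elements differ; a stereocentre at a saturated ring carbon is drawn R in compound 3 and S in compound 4; a stereocentre at a saturated ring carbon is drawn S in compound 3 and R in compound 4; a stereocentre at a saturated chain carbon is drawn S in compound 3 and R in compound 4; a stereocentre at a saturated ring carbon is drawn R in compound 3 and S in compound 4. Among the compounds with values here, no pair of measured compounds differing in one place exists in this set, so there is no measured step to lean on.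

Since the three measured values all fall within the scatter of one another, the step from compound 3 to compound 4 is expected to be small, with a slightly lower number estimated, at a 1.6-fold lower number from compound 3 to compound 4 (0.20 log units; within the scatter), but not clearly beyond the scatter. Compound 4 is therefore estimated to give 18000 nM in this assay, within a range from 7000 nM to 45000 nM.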

Compound 4, half-maximal inhibitory concentration: 23800 nM
Compound 4: middle estimate off by 1.3-fold (0.12 log units), on the low side; low and high end bracket the measured number.
By their numbers in this assay, from the lowest: compounds 1, 2, 4 and 3 (each within the scatter of the next).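

Within the data shown here, the four compounds now give the first pairs that differ in one place. In this assay, inverting four of the five stereo elements gives a 1.2-fold lower number from compound 3 to compound 4 (0.08 log units; within the scatter), and this comparison speaks to configuration alone because nothing else separates the two structures: the fact that compounds 3 and 4 differ only in the configuration as drawn

Putting 3,4-dimethoxyphenyl in place of phenyl on the saturated chain carbon bound to an oxygen gives a 1.5-fold higher number from compound 2 to compound 4 (0.19 log units; within the scatter), and the same exchange on the double-bonded chain carbon gives a 1.6-fold higher number from compound 1 to compound 4 (0.21 log units; within the scatter). Thus, in these three pairs, neither the inversion of the four stereo elements nor either exchange of phenyl for 3,4-dimethoxyphenyl moves the number beyond the scatter, a finding that holds for these four compounds only.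

The compounds shown leave open whether inverting a single stereocentre, rather than four together, would give a readable difference. They also leave open whether an amine or a carboxylic acid on an aryl ring, or a longer chain in place of the styryl chain, would shift the number in this assay beyond the scatter.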